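A few compounds are considered here, and "the series" means these few. Any claim that something is new, unique, unknown or untested is made for them only; others in the source may bear on it.

Measured so far in a functional assay on HL-60 cells (Homo sapiens) for inhibition, read by MTT assay, with a stated time of 72 h; a lower number here means a stronger inhibitor, a higher number a weaker inhibitor:
- Compound 1 `Cc1ccc(C)c(N2CCN(C(=O)c3oc(C)nc3-c3ccccc3)CC2)c1`: 31.3 nM
- Compound 2 `C=C(C)c1ccc(N2CCN(C(=O)c3oc(C)nc3-c3ccccc3)CC2)cc1`: "not active" (no number reported)

Compound 2 has no single number to stand on. In this assay compound 2 is reported only as "not active" (no number reported), so it cannot be placed on the numerical scale. Going by the values given here, compound 1, at 31.3 nM, is the only compound here with a measured concentration.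

Compound 3 `CC(=O)c1ccc(N2CCN(C(=O)c3oc(C)nc3-c3ccccc3)CC2)cc1` keeps the rest of the structure of compound 2 and changes one group. The change is acetyl in place of 1-methylethenyl on an aromatic carbon, para to a large group.

With no number for compound 2, the size of this step cannot be stated as a difference between two values. The expected direction is toward a stronger result in this assay, but only a modest one, ending at a weaker level than compound 1 shows at 31.3 nM. There is also a real chance that no number is reported at all.

For compound 3 the estimated half-maximal inhibitory concentration is 800 nM, with an expected range from 60 nM to 8000 nM.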

Compound 3, half-maximal inhibitory concentration: "not active" (no number reported)
No number was reported for compound 3, so the estimate cannot be set against anything.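

In this assay, going by these compounds alone, compound 2 and compound 3 are both reported as "not active" with no number, so no step between them can be read. The compounds shown leave open whether acetyl in place of 1-methylethenyl changes activity at all. Nothing available here bears on this result.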